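The compounds below may be only part of what the source reports. "The series", "measured", "known", "first", "only" and "open" are said of these compounds alone.

Measured compounds:
compound 1, `Cc1nc(-c2nc[nH]n2)ccc1-c1cnc2c(n1)N(CCC1CCOCC1)C(=O)CN2`; in an ADME assay on the whole organism for pharmacokinetics, with Rattus norvegicus as the target, at a dose of 2 mg/kg by the intravenous route (a higher number here means faster removal of the compound, a lower number slower removal), compound 1 gives 37.9 mL/min/kg.
compound 2, `Cc1nc(-c2nc[nH]n2)ccc1-c1cnc2c(n1)N([C@H]1CC[C@@H](O)CC1)C(=O)CN2`; in this assay compound 2 gives "not determined" (no result reported).

Compound 2 therefore stands nowhere on the numbers: no value in this assay was reported for it. Compound 3, `COCCN1C(=O)CNc2ncc(-c3ccc(-c4nc[nH]n4)nc3C)nc21`, differs from compound 2 by 2-methoxyethyl in place of 4-hydroxycyclohexyl on an amide-type nitrogen in a ring. Within the data shown here, no measured pair sets a step, and compound 1 at 37.9 mL/min/kg supplies the only number in this assay, so the direction of the change from compound 2 to compound 3 cannot be read from the data; a step within the usual scatter is the plainest expectation. Compound 3 is expected to give about 35 mL/min/kg in this assay, within 15 mL/min/kg to 70 mL/min/kg.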

Compound 3, clearance: 34.7 mL/min/kg
Compound 3: the middle estimate sits 1.0-fold (0.00 log units) above what was measured, within the range that was stated.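

Among these compounds, at this position on the amide-type nitrogen in a ring, the first readable pair in this assay shows a 1.1-fold lower number from compound 1 to compound 3 (0.04 log units; within the scatter), so methoxy in place of oxan-4-yl on the saturated chain carbon moves the number no further than the usual scatter. Nothing available explains this result. The step from compound 2 to compound 3 cannot be read, as compound 2 has no value. Going by these compounds, what remains open is how the 4-hydroxycyclohexyl group of compound 2 compares, and whether an amine, a carboxylic acid or a longer chain at this nitrogen would also stay within the scatter.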